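The source may report more compounds than this note shows. Statements on the series, on what has been measured and on what is new or still open speak of the compounds shown alone.

Compound 1 `COc1ccc(Cn2c(N)nc3cc(Cl)c(Cl)cc32)cc1`: 27000 nM
Compound 2 `Clc1ccc(Cn2c(Cl)nc3cc(Cl)c(Cl)cc32)cc1`: > 100000 nM

In a functional assay on CEM-SS cells (Homo sapiens) for cytotoxicity (a higher number here means a weaker inhibitor, a lower number a stronger inhibitor), compound 1 gives 27000 nM, a measured number. Compound 2 gives > 100000 nM, which is a limit of the assay and not a number. Its exact place on the scale is therefore unknown.

Compound 3 `COc1ccc(Cn2c(Cl)nc3cc(Cl)c(Cl)cc32)cc1` has methoxy in place of chloro on an aromatic carbon, para to a large group (methoxy in place of chloro on an aromatic carbon). Among the compounds with values here, no measured pair of compounds shows this change alone, so any expectation about it is loose. Compound 1 also carries methoxy and gives 27000 nM, so a modest move toward a lower number is expected. A second limit reading would still be no surprise. The estimated change is an at least 1.6-fold lower number from compound 2 to compound 3 (0.22 log units; that floor lies within the scatter). For compound 3 the expected value is 60000 nM, with an estimated range of 25000 nM to 100000 nM.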

Compound 3, half-maximal inhibitory concentration: > 100000 nM
Compound 3: no number, only a limit; the forecaster's own chance of this, stated with the estimate: 45%; at least 1.6-fold (0.22 log units) between middle value and limit.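

In this assay compound 3 gives > 100000 nM, a limit of the assay and not a number. Within the data shown here, the change of methoxy in place of chloro cannot be read, because compound 2 and compound 3 both stop at the same limit: the limit of > 100000 nM in this assay, at which 2 of the 3 values shown sit. What compound 3 adds is the first single change that can be read: with the methoxy kept, chloro in place of amino on an aromatic carbon gives an at least 3.7-fold higher number from compound 1 to compound 3 (0.56 log units; beyond the scatter), so the amino group's place on the shared core matters in this assay.

As far as these compounds go, whether methoxy and chloro differ at all when they sit para to a large group stays open, and a partner of compound 2 carrying amino would be needed to test it. From the compounds shown here alone, how a methylamino group or a hydroxyl in place of that amino would read also remains unknown.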